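Ester Tail Changes and Rat Microsome Half-Life

The compounds below may be only part of what the source reports. "The series", "measured", "known", "first", "only" and "open" are said of these compounds alone.

Measured so far:
- compound 1 `CCOC(=O)/C=C/c1ccc(NC(=O)C2(NC(=O)c3ccc4c(C5CCCC5)c(-c5ncc(Cl)cn5)n(C)c4c3)CCC2)cc1OCC`: 3.07 h
- compound 2 `CCOc1cc(NC(=O)C2(NC(=O)c3ccc4c(C5CCCC5)c(-c5ncc(Cl)cn5)n(C)c4c3)CCC2)ccc1/C=C/C(=O)OCCOCCOC`: 1.07 h
- compound 3 `CCOc1cc(NC(=O)C2(NC(=O)c3ccc4c(C5CCCC5)c(-c5ncc(Cl)cn5)n(C)c4c3)CCC2)ccc1/C=C/C(=O)OCC(N)=O`: 0.383 h

In an ADME assay (liver) for pharmacokinetics, with Liver microsome (Rattus norvegicus) as the target, using microsomes (on this read-out lower numbers stand for a shorter-lived compound and higher numbers for a longer-lived compound), compound 1 gives 3.07 h, the highest of the three numbers; it is followed by compound 2 with 1.07 h and then compound 3 with 0.383 h. Three compounds share one core and differ only in the ester tail. Compound 4 `CCOc1cc(NC(=O)C2(NC(=O)c3ccc4c(C5CCCC5)c(-c5ncc(Cl)cn5)n(C)c4c3)CCC2)ccc1/C=C/C(=O)OCC(=O)N1CCOCC1` is not yet measured. Its change from compound 1 is (morpholin-4-yl)carbonyl in place of methyl on a saturated chain carbon bound to an oxygen next to a carbonyl group. Going by the values given here, two measured steps bear on this: a 2.9-fold lower number from compound 1 to compound 2 (0.46 log units; beyond the scatter) and an 8.0-fold lower number from compound 1 to compound 3 (0.90 log units; beyond the scatter). Both enlarge the tail at the same place, and both lower the number beyond the scatter. The entering group in compound 4 carries a carbonyl like the group entering in compound 3, yet is larger, closer in size to the group entering in compound 2. A modest step down is therefore expected for compound 4, estimated as a 4.4-fold lower number from compound 1 to compound 4 (0.64 log units; beyond the scatter). Compound 4 is expected to give about 0.7 h in this assay, with a range from 0.3 h to 1.6 h.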

Compound 4, half-life: 0.733 h
For compound 4 the middle estimate is 1.0-fold (0.02 log units) below the measured one, and the stated range covers the measured number.
By their numbers in this assay, from the lowest: compounds 3, 4 and 2 (each within the scatter of the next, the first and the last beyond it); then compound 1.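

In this assay, the (morpholin-4-yl)carbonyl group lowers the number clearly, with a 4.2-fold lower number from compound 1 to compound 4 (0.62 log units; beyond the scatter), so all three enlarged tails shown now fall beyond the scatter on the same side of compound 1. The new tail cannot be separated from either earlier enlarged tail: morpholin-4-yl in place of amino on a carbonyl carbon gives a 1.9-fold higher number from compound 3 to compound 4 (0.28 log units; within the scatter), and the comparison with the (2-methoxyethoxy)methyl tail gives a 1.5-fold lower number from compound 2 to compound 4 (0.16 log units; within the scatter), although compound 2 and compound 3 do differ beyond the scatter. No measurement here accounts for why these tails change the half-life.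

Still open, as far as these compounds go, is how a plain longer chain, such as propyl, would compare at this saturated chain carbon. A tail ending in a carboxylic acid or an amine also remains unexplored among the compounds shown.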